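Removing the Methoxybenzyl Ether from a Macrocyclic Lactam

This account rests on a few compounds, and the source may have more. Where it says the series, first, only, none or still open, it means among the compounds named here.

Two macrocycles have been tested in a functional assay on DU-145 cells (Homo sapiens) for antiproliferative activity, read by WST assay, with a stated time of 3 days; on this read-out lower numbers stand for stronger inhibition and higher numbers for weaker inhibition. Compound 1 `C/C1=C/C=C/C(=O)N[C@@H](C=O)C/C(C)=C/COCC/C=C/C(=O)C1` gives 10200 nM. Compound 2 `COc1ccc(COC[C@H]2C/C(C)=C/COCC/C=C/C(=O)C/C(C)=C\C=C\C(=O)N2)cc1` gives 7360 nM, and the step of a 1.4-fold lower number from compound 1 to compound 2 (0.14 log units; within the scatter) lies within the scatter, so the two numbers cannot be told apart. Compound 3 `C/C1=C/C=C/C(=O)N[C@@H](CO)C/C(C)=C/COCC/C=C/C(=O)C1` differs from compound 2 by hydrogen in place of 4-methoxybenzyl on an oxygen on a saturated carbon, leaving a hydroxymethyl in place of the ((4-methoxybenzyl)oxy)methyl. Going by the values given here, no measured step tests exactly this change; the only related one, a 1.4-fold lower number from compound 1 to compound 2 (0.14 log units; within the scatter), stayed within the scatter. The step of a 1.2-fold higher number from compound 2 to compound 3 (0.06 log units; within the scatter) is therefore expected to be small. Compound 3 is estimated at 8500 nM, with a range from 3000 nM to 25000 nM.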

Compound 3, half-maximal inhibitory concentration: > 12500 nM
Compound 3 gave a limit, no number; the forecaster's own chance of this, stated with the estimate: 10%; middle value at least 1.4-fold (0.16 log units) away from the limit.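

Compound 3 gives no number, only a limit: the limit of > 12500 nM in this assay, at which 1 of the 3 values shown sits. Measured against that limit, hydrogen in place of 4-methoxybenzyl gives an at least 1.6-fold higher number from compound 2 to compound 3 (0.23 log units; that floor lies within the scatter), and hydroxymethyl in place of formyl gives an at least 1.2-fold higher number from compound 1 to compound 3 (0.08 log units; that floor lies within the scatter). Exposing the hydroxymethyl on this saturated ring carbon therefore brings no stronger inhibition, although the size of either step remains unknown.

The compounds shown leave open how far compound 3 lies beyond its limit. They also leave open whether an amine or a carboxylic acid at this position would give a lower number.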